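Swapping 3-chlorophenyl for 4-chlorophenyl on a shared core

A few compounds are considered here, and "the series" means these few. Any claim that something is new, unique, unknown or untested is made for them only; others in the source may bear on it.

In an ADME assay on Vero cells (Chlorocebus sabaeus) for cytotoxicity, read by sulforhodamine B assay, with a stated time of 72 h (a higher number here means a weaker inhibitor, a lower number a stronger inhibitor), compound 1 `CN1Cc2ccc(OCc3ccc([N+](=O)[O-])cc3)cc2[C@@H](O)C1` reports only a limit, > 50000 nM. Compound 2 `CN1Cc2ccc(OCc3ccc(Oc4ccc(F)cc4)cc3)cc2[C@@H](O)C1` gives 5600 nM. Compound 3 `CN1Cc2ccc(OCc3ccc(-c4cccc(Cl)c4)cc3)cc2[C@@H](O)C1` gives 25500 nM, the higher of the two numbers that are not limits. Compound 4 `CN1Cc2ccc(OCc3ccc(-c4ccc(Cl)cc4)cc3)cc2[C@@H](O)C1` carries 4-chlorophenyl in place of 3-chlorophenyl on an aromatic carbon. The measured steps all exchange a whole group, and none only moves the chlorine. They are an at least 8.9-fold lower number from compound 1 to compound 2 (0.95 log units; beyond the scatter), an at least 1.9-fold lower number from compound 1 to compound 3 (0.29 log units; that floor lies within the scatter) and a 4.6-fold higher number from compound 2 to compound 3 (0.66 log units; beyond the scatter). The first and last lie beyond the scatter, while the floor of the middle one lies within it. They are therefore only a loose guide, and no change beyond the scatter is expected. The expected step is a 1.2-fold lower number from compound 3 to compound 4 (0.06 log units; within the scatter). Compound 4 is estimated at 22000 nM, with an expected range of 9000 nM to 50000 nM.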

Compound 4, half-maximal inhibitory concentration: 21700 nM
Estimate against measurement, compound 4: 1.0-fold (0.01 log units) above; low and high end bracket the measured number.
By their numbers in this assay, from the lowest: compound 2; then compounds 4 and 3 (each within the scatter of the next). At a limit, above all of these: compound 1.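

In this assay, moving the chlorine alone gives a 1.2-fold lower number from compound 3 to compound 4 (0.07 log units; within the scatter), so this position does not separate 3-chlorophenyl from 4-chlorophenyl. Replacing 4-fluorophenoxy with 4-chlorophenyl gives a 3.9-fold higher number from compound 2 to compound 4 (0.59 log units; beyond the scatter), which shows that the group exchange, not the chlorine's place, carries the larger difference. The step of an at least 2.3-fold lower number from compound 1 to compound 4 (0.36 log units; beyond the scatter) starts from a limit and not from a number: the limit of > 50000 nM in this assay, at which 1 of the 4 values shown sits.

As far as these compounds go, whether an amine or a carboxylic acid in place of the chlorine would shift the number beyond the scatter stays open.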